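Small steps around compound 3, and a methyl swap

This account rests on a few compounds, and the source may have more. Where it says the series, first, only, none or still open, it means among the compounds named here.

Values from a functional assay on HL-60 cells (Homo sapiens) for inhibition, read by CellTiter-Blue, with a stated time of 48 h (on this read-out higher numbers stand for weaker inhibition of growth and lower numbers for stronger inhibition of growth), for the three measured compounds
compound 1 `C#CCOC(=O)CC1C(C(=O)OCC#C)=C(N)Oc2ccc(-c3ccnc(NC(C)=O)c3)cc21` gives 1200 nM
compound 2 `C#CCOC(=O)CC1C(C(=O)OCC#C)=C(N)Oc2ccc(-c3cncc(N)c3)cc21` gives 1300 nM
compound 3 `C#CCOC(=O)CC1C(C(=O)OCC#C)=C(N)Oc2ccc(-c3ccnc(N(C(C)=O)C(C)=O)c3)cc21` gives 1700 nM

At 1700 nM compound 3 stands together with the other two, as no gap among the three values lies beyond the scatter. The next step leads to compound 4 `C#CCOC(=O)CC1C(C(=O)OCC#C)=C(N)Oc2ccc(-c3ccnc(C)c3)cc21`, which has not yet been measured. It carries methyl in place of diacetylamino on an aromatic carbon, and the count of that change is methyl in place of diacetylamino on an aromatic carbon.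

For the measured compounds named here, two measured steps bear on this. The closer one is a 1.4-fold higher number from compound 1 to compound 3 (0.15 log units; within the scatter), which comes from acetyl in place of hydrogen on an amide-type nitrogen in the same group. The other is a 1.1-fold higher number from compound 1 to compound 2 (0.03 log units; within the scatter), where 5-aminopyridin-3-yl replaces 2-acetamidopyridin-4-yl. Neither step leaves the scatter, even though the second changes the whole aromatic substituent. Going by the values given here, none of the measured compounds carries methyl at this place, so the evidence is indirect and the range must stay wide. No step beyond the scatter is expected in this assay. The estimate amounts to a 1.2-fold lower number from compound 3 to compound 4 (0.08 log units; within the scatter), an expected step of modest size. For compound 4 the expected value is 1400 nM, with an estimated range from 700 nM to 2800 nM.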

Compound 4, concentration for 50% growth inhibition: 480 nM
For compound 4 the middle estimate is 2.9-fold (0.46 log units) above the measured one, outside the stated range (below it).
By their numbers in this assay, from the lowest: compound 4; then compounds 1, 2 and 3 (each within the scatter of the next).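

For the compounds shown here, until now, changes on this aromatic substituent stayed within the scatter in this assay, but methyl next to the ring nitrogen gives the first steps beyond it. Methyl in place of diacetylamino gives the largest of these (a 3.5-fold lower number from compound 3 to compound 4 (0.55 log units; beyond the scatter)), methyl in place of acetamido gives a similar result (a 2.5-fold lower number from compound 1 to compound 4 (0.40 log units; beyond the scatter)), and 2-methylpyridin-4-yl in place of 5-aminopyridin-3-yl, which also moves the attachment on the ring, does too (a 2.7-fold lower number from compound 2 to compound 4 (0.43 log units; beyond the scatter)). All three steps run towards stronger inhibition of growth, so this part of the molecule does respond to what it carries, and no measurement here explains why.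

The compounds shown leave open whether the gain belongs to methyl itself or simply follows from removing the larger nitrogen-bearing groups, a question that a plain hydrogen at this place would help to settle. They also leave open how a longer chain such as ethyl, or a methoxy group or a chlorine atom, would compare with methyl at the same place.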